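A few compounds are considered here, and "the series" means these few. Any claim that something is new, unique, unknown or untested is made for them only; others in the source may bear on it.

Among the compounds with values here, in a functional assay on HCT-116 cells (Homo sapiens) for cytotoxicity, read by MTT assay (a higher number here means a weaker inhibitor, a lower number a stronger inhibitor), only two compounds have numbers so far. Compound 1 `CCn1cc(-c2nc3ccc([N+](=O)[O-])cc3o2)c(=O)c2cc(F)c(N3CCNC(C)C3)c(F)c21` gives 1100 nM and compound 2 `CCn1cc(C(=O)Nc2cccc([N+](=O)[O-])c2)c(=O)c2cc(F)c(N3CCNC(C)C3)c(F)c21` gives 2710 nM as the higher of the two numbers. That makes compound 2 the weaker inhibitor of the pair, and the gap between them lies beyond the usual scatter of repeated measurements.

Compound 3 `CCn1cc(C(=O)Nc2nccs2)c(=O)c2cc(F)c(N3CCNC(C)C3)c(F)c21` keeps the shared core of compound 2 and changes one place: 1,3-thiazol-2-yl stands in place of 3-nitrophenyl on an amide-type nitrogen (1,3-thiazol-2-yl in place of 3-nitrophenyl on an amide-type nitrogen). Within the data shown here, no measured pair yet shows what a change at this place does, so the data offer no direction for it. The expectation in this assay is therefore no step beyond the scatter, with compound 2 at 2710 nM as the only anchor. Put in numbers, the estimate is an expected step of a 1.1-fold lower number from compound 2 to compound 3 (0.04 log units; within the scatter) that stays within the scatter. The estimate for compound 3 is 2500 nM with an expected range from 800 nM to 9000 nM as the likely span. Among the measured compounds shown here, only two measured values support it.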

Compound 3, half-maximal inhibitory concentration: 8660 nM
Beside the measured number, compound 3's estimate is 3.5-fold (0.54 log units) below it; measured number inside the range.
By their numbers in this assay, from the lowest: compound 1; then compound 2; then compound 3.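

In this assay, within the data shown here, exchanging 3-nitrophenyl for 1,3-thiazol-2-yl on the amide-type nitrogen gives a 3.2-fold higher number from compound 2 to compound 3 (0.50 log units; beyond the scatter) and so a weaker inhibitor, which is the first sign that the number responds to what sits at this place. This one exchange alters several things together: a six-membered aromatic ring of carbon only gives way to a five-membered aromatic ring with 2 hetero atoms, sulfur enters, and the nitro group leaves. No measurement on hand shows which of these changes accounts for the rise.

As far as these compounds go, it remains open whether the nitro group or the ring itself drives this step, and a plain phenyl group on the same nitrogen would help to separate the two. Also unsettled is whether the trend holds beyond these aromatic groups, for example with a 3-aminophenyl group, which carries an amine where the nitro group stood, or with a simple ethyl chain on that nitrogen.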